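The source may hold more compounds than are shown below. What is called first, only, known or untested is meant among the compounds shown, and "the series" means these compounds.

In a functional assay on DU-145 cells (Homo sapiens) for antiproliferative activity, read by sulforhodamine B assay, with a stated time of 3 days (on this read-out lower numbers stand for stronger inhibition of growth and higher numbers for weaker inhibition of growth), three compounds have been measured:
- Compound 1 `O=C(Nc1cccc(Nc2ncc(F)c(Nc3ccc(F)cc3)n2)c1)c1cnccn1`: 26400 nM
- Compound 2 `O=C(c1cccc(Nc2ncc(F)c(Nc3ccc(F)cc3)n2)c1)N1CCCCC1`: 13000 nM
- Compound 3 `CN(C)c1ccc(C(=O)Nc2cccc(Nc3ncc(F)c(Nc4ccc(F)cc4)n3)c2)cc1`: > 10000 nM (a limit)

Compound 3 has no exact number and stands only at the limit of > 10000 nM in this assay, at which 1 of the 3 values shown sits. Compound 4 `O=C(Nc1cccc(Nc2ncc(F)c(Nc3ccc(F)cc3)n2)c1)c1ccccc1` differs from it in one place: hydrogen in place of dimethylamino on an aromatic carbon. This puts hydrogen in place of dimethylamino on an aromatic carbon. The step that brings in 4-(dimethylamino)phenyl is a step that the limit leaves unreadable from compound 1 to compound 3, so it gives no size to reverse. For the measured compounds named here, the only readable step is a 2.0-fold lower number from compound 1 to compound 2 (0.31 log units; beyond the scatter), a modest one involving a different change. A large step in this assay is therefore not expected, and no direction can be assigned with confidence. The estimate implies an expected step that the limit leaves unreadable from compound 3 to compound 4. For compound 4, the estimated value is 15000 nM, with an expected range of 6000 nM to 35000 nM.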

Compound 4, concentration for 50% growth inhibition: > 10000 nM
Compound 4 ended at the assay's limit (the forecaster's own chance of this, stated with the estimate: 35%); the middle value is on the limit's open side.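

For the compounds shown here, compound 3 and compound 4 both stand at a limit, and no step from compound 1, compound 2 or compound 3 to compound 4 can be read: the limit of > 10000 nM in this assay, at which 2 of the 4 values shown sit. The compounds shown leave open whether hydrogen in place of dimethylamino changes the result in this assay at all.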